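Hydroxy to fluoro swap, tested on two aryl cores

The source may hold more compounds than are shown below. What is called first, only, known or untested is meant among the compounds shown, and "the series" means these compounds.

Compound 1 `COc1ccc(-c2ccc3ncn(-c4cc(OC)c(OC)c(OC)c4)c3c2)cc1O` gives 200 nM in a functional assay on A549 cells (Homo sapiens) for antiproliferative activity, read by MTT assay, with a stated time of 72 h; on this read-out higher numbers stand for weaker inhibition and lower numbers for stronger inhibition. Compound 2 `COc1ccc(-c2ccc3ncn(-c4cc(OC)c(OC)c(OC)c4)c3c2)cc1F` gives 1430 nM in this assay; the change is fluoro in place of hydroxy on an aromatic carbon and it made a 7.2-fold higher number from compound 1 to compound 2 (0.85 log units; beyond the scatter). Compound 3 `COc1cc(-n2cnc3ccc(-c4ccc(O)cc4)cc32)cc(OC)c1OC` gives 5090 nM in this assay, the highest number of the three; its core differs from compound 1 by 4-hydroxyphenyl in place of 3-hydroxy-4-methoxyphenyl on an aromatic carbon, with a 25-fold higher number from compound 1 to compound 3 (1.41 log units; beyond the scatter) and a 3.6-fold higher number from compound 2 to compound 3 (0.55 log units; beyond the scatter). Compound 4 `COc1cc(-n2cnc3ccc(-c4ccc(F)cc4)cc32)cc(OC)c1OC` is unmeasured and differs from compound 3 by fluoro in place of hydroxy on an aromatic carbon. This is the same kind of change as from compound 1 to compound 2, not the same: there the fluoro stands ortho to a methoxy group and meta to a large group, here para to a large group. For compound 4 the expected step is a 3.9-fold higher number from compound 3 to compound 4 (0.59 log units; beyond the scatter), resting on a 7.2-fold higher number from compound 1 to compound 2 (0.85 log units; beyond the scatter) and on compound 3 already giving 5090 nM. Compound 4 is estimated at 20000 nM, between 6000 nM and 70000 nM.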

Compound 4, half-maximal inhibitory concentration: 6740 nM
Compound 4: middle estimate off by 3.0-fold (0.47 log units), on the high side; the measured number falls inside the stated range.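

The change of hydroxy to fluoro does not carry over at one size between the two cores in this assay: the same change on two cores in this assay, a 7.2-fold higher number (0.85 log units; beyond the scatter) from compound 1 to compound 2 and a 1.3-fold higher number (0.12 log units; within the scatter) from compound 3 to compound 4, 5.4-fold (0.73 log units) apart, beyond the scatter of two such steps

On the core of compound 3 the step reads a 1.3-fold higher number from compound 3 to compound 4 (0.12 log units; within the scatter), so hydroxy and fluoro cannot be told apart there, while changing the aryl group still counts for much more, with a 4.7-fold higher number from compound 2 to compound 4 (0.67 log units; beyond the scatter) and a 34-fold higher number from compound 1 to compound 4 (1.53 log units; beyond the scatter). With one pair on each core, these numbers do not show why the two steps differ, nor which size is typical of the series.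

Left open is how an amine or a chloro group in place of the hydroxy would behave on either core.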